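Swapping Fluoro for Chloro at a Sharp Potency Peak

The compounds below may be only part of what the source reports. "The series", "measured", "known", "first", "only" and "open" are said of these compounds alone.

Of the compounds shown here, three sharing one core have been measured in a functional assay on HCC 2998 cells (Homo sapiens) for antiproliferative activity; a lower number here means a stronger inhibitor of growth, a higher number a weaker inhibitor of growth. Compound 1 `COc1ccc(-c2nc3ccccc3s2)cc1OC` gives 42500 nM, compound 2 `COc1ccc(-c2nc3cc(F)ccc3s2)cc1F` gives 13700 nM, and compound 3 `COc1ccc(-c2nc3cc(F)ccc3s2)cc1OC` gives 0.25 nM. Compound 3 therefore has the lowest number of the three and is the strongest growth inhibitor among them.

Compound 4 `COc1ccc(-c2nc3cc(Cl)ccc3s2)cc1OC` differs from compound 3 in one place: chloro in place of fluoro on an aromatic carbon. In words, this is chloro in place of fluoro on an aromatic carbon.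

Among the compounds with values here, two measured steps bear on this change. Putting fluoro in place of hydrogen at this carbon gave a 170000-fold lower number from compound 1 to compound 3 (5.23 log units; beyond the scatter). Elsewhere on the molecule, methoxy in place of fluoro gave a 55000-fold lower number from compound 2 to compound 3 (4.74 log units; beyond the scatter). Both steps are large and beyond the scatter, so among these compounds a single small edit can move the number enormously. Neither step tests chloro, however, so the size of this step remains very uncertain. The number of compound 3 is so low, at 0.25 nM, that a sizeable rise seems more likely than a further fall.

The expected change is an 80-fold higher number from compound 3 to compound 4 (1.90 log units; beyond the scatter), towards weaker growth inhibition. For compound 4 the estimated value is 20 nM, with an expected range from 0.3 nM to 3000 nM.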

Compound 4, concentration for 50% growth inhibition: 4880 nM
Beside the measured number, compound 4's estimate is 240-fold (2.39 log units) below it, outside the stated range (above it).
By their numbers in this assay, from the lowest: compound 3; then compound 4; then compound 2; then compound 1.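

In this assay, the identity of the group at this carbon matters as much as its presence: exchanging fluoro for chloro gives a 20000-fold higher number from compound 3 to compound 4 (4.29 log units; beyond the scatter), a step about as large as those that first made compound 3 stand out. Chloro in place of hydrogen at the same carbon gives only an 8.7-fold lower number from compound 1 to compound 4 (0.94 log units; beyond the scatter), so among these compounds, chloro retains just a small part of the fall in the number seen with fluoro, and the sharp peak at compound 3 does not extend to this other halogen. Nothing measured here explains why two groups of one heavy atom each behave so differently.

On these data alone, with only hydrogen, fluoro and chloro compared at this carbon, it remains open whether a bromo, a methyl or a nitrile there would give a number close to that of compound 3, close to that of compound 4, or somewhere in the wide gap between them. It is also open whether chloro would fare differently with other groups in place of the two methoxy groups on the other ring, since every step at this carbon shown here keeps those two groups unchanged.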